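This account rests on a few compounds, and the source may have more. Where it says the series, first, only, none or still open, it means among the compounds named here.

Compound 1 `O=C(CCCCCNC(=S)NN=C(c1ccccn1)c1ccccn1)NO`: 2180 nM
Compound 2 `Cc1ccccc1/C(=N/NC(=S)NCCCCCC(=O)NO)c1ccccc1`: 4220 nM
Compound 3 `C/C(=N\NC(=S)NCCCCCC(=O)NO)c1cccc(Br)c1`: 520 nM

These three compounds were tested in a functional assay on K562/A02 cells (Homo sapiens) for antiproliferative activity, read by MTT assay; a lower number here means a stronger inhibitor, a higher number a weaker inhibitor. Going by the values given here, compound 2 gives 4220 nM, the highest number of the three, although that value lies within the scatter of the one for compound 1. Compound 3 gives 520 nM. Among the compounds with values here, this number stands clearly lower than the one for compound 2.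

Compound 4 `O=C(CCCCCNC(=S)N/N=C(\c1ccccc1)c1ccc([N+](=O)[O-])cc1)NO` has not yet been measured. It departs from compound 2 in one place: 4-nitrophenyl in place of 2-methylphenyl on a carbon with a double bond to nitrogen. In words, 4-nitrophenyl stands in place of 2-methylphenyl on a carbon with a double bond to nitrogen.

Within the data shown here, no measured pair of compounds differs in a single place, so the data offer no direct guide to the size of this step. The closest guidance comes from compound 1 at 2180 nM, which also carries two aromatic groups on that carbon and lies within the scatter of compound 2. Compound 3 at 520 nM has a different pair of groups there, so it is a weaker guide. A small move toward a lower number is therefore expected, probably not beyond the scatter. The expected step is a 1.7-fold lower number from compound 2 to compound 4 (0.23 log units; within the scatter). For compound 4 the estimated value is 2500 nM, with an expected range from 800 nM to 7000 nM.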

Compound 4, half-maximal inhibitory concentration: 4530 nM
Estimate against measurement, compound 4: 1.8-fold (0.26 log units) below, within the range that was stated.
By their numbers in this assay, from the lowest: compound 3; then compounds 1, 2 and 4 (each within the scatter of the next, the first and the last beyond it).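

In this assay, going by these compounds alone, the change from 2-methylphenyl to 4-nitrophenyl on a carbon with a double bond to nitrogen gives a 1.1-fold higher number from compound 2 to compound 4 (0.03 log units; within the scatter), the first step in this set that isolates a single place. Here, a 4-nitrophenyl group, which brings hydrogen-bond acceptors and a double bond outside the aromatic ring that 2-methylphenyl lacks, can stand in place of 2-methylphenyl without moving the number beyond the scatter. Within the data shown here, no measurement at hand explains this outcome, so the step records only that this exchange leaves the read-out within the scatter.

The compounds shown leave open whether an amine or a carboxylic acid on the aromatic ring in place of the nitro group would also stay within the scatter of compound 2. They also leave open whether a methyl group in place of the unsubstituted phenyl on that same carbon would alter the number when 4-nitrophenyl is kept, since this single step says nothing about the other group on that carbon.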